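The source may report more compounds than this note shows. Statements on the series, on what has been measured and on what is new or still open speak of the compounds shown alone.

In a physicochemical assay for lipophilicity, read by LC-MS, measured as octanol-water partition, with a stated time of 2 h, at pH 7.4, tested at 1 uM (a higher number here means a more lipophilic compound, a lower number a more polar compound), compound 1 (`Cc1cccc(-c2ccc(O[C@H]3O[C@H](CO)[C@@H](O)[C@H](O)[C@@H]3O)c(Cl)c2)c1`) gives 3 and compound 2 (`Cc1ccc(-c2ccc(O[C@H]3O[C@H](CO)[C@@H](O)[C@H](O)[C@@H]3O)c(Cl)c2)cc1`) gives 3.3 and so stands within the scatter of compound 1, while compound 3 (`OC[C@H]1O[C@H](Oc2ccc(-c3ccc(Cl)c(C(F)(F)F)c3)cc2Cl)[C@@H](O)[C@@H](O)[C@@H]1O`) has "not determined" (no result reported) as its entry. Compound 4 (`CC(=O)c1ccc(-c2ccc(O[C@H]3O[C@H](CO)[C@@H](O)[C@H](O)[C@@H]3O)c(Cl)c2)cc1`) carries acetyl in place of methyl on an aromatic carbon relative to compound 2. Among the compounds with values here, the one measured step (a number 0.30 log units higher from compound 1 to compound 2 (within the scatter)) puts 4-methylphenyl in place of 3-methylphenyl and keeps the methyl, and no measured step gives a size for this change. A moderate fall beyond the scatter in this assay is nonetheless expected, as a judgement from the structural change alone. The estimated step (a number 0.70 log units lower from compound 2 to compound 4 (beyond the scatter)) carries that expectation. Compound 4 is expected at 2.6 with 2.2 and 3 as the ends of the estimated range.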

Compound 4, distribution coefficient: 2.1
Compound 4: the middle estimate sits 0.50 log units above what was measured; the whole stated range lies above it.
By their numbers in this assay, from the lowest: compound 4; then compounds 1 and 2 (each within the scatter of the next).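

Within the data shown here, replacing methyl by acetyl at this place, para to a large group, gives the first step beyond the scatter in this assay, with a number 1.20 log units lower from compound 2 to compound 4 (beyond the scatter). Set against the 3-methylphenyl compound, the change points the same way, with a number 0.90 log units lower from compound 1 to compound 4 (beyond the scatter), so the drop does not depend on which methyl compound serves as the reference. Nothing at hand accounts for the size of this step. The compounds shown leave open whether an amine, a carboxylic acid or a longer chain at this place would follow acetyl. They also leave open whether acetyl would give a step of this size at the place the methyl occupies in compound 1.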